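This account rests on a few compounds, and the source may have more. Where it says the series, first, only, none or still open, it means among the compounds named here.

For the measured compounds named here, in a functional assay on UO-31 cells (Homo sapiens) for cytotoxicity, read by sulforhodamine B assay, with a stated time of 48 h, tested at 100 uM (a higher number here means a weaker effect of the compound at the concentration tested, a lower number a stronger effect), compound 2 `COc1ccc(C(=O)/C=C/c2cc(-c3cc(OC)c(OC)c(OC)c3)n[nH]2)cc1OC` gives -96%, the lowest of the two numbers measured so far; the nearest is compound 1 `COc1cc(-c2cc(/C=C/C(=O)c3ccc(Cl)c(Cl)c3)[nH]n2)cc(OC)c1OC`, which gives 18%. Going by the values given here, the single measured step, a number 114 percentage points lower from compound 1 to compound 2 (beyond the scatter), shows that exchanging the whole aryl group on the carbonyl carbon moved the read-out a long way. Compound 3 `COc1ccc(C(=O)/C=C/c2cc(-c3cc(OC)c(OC)c(OC)c3)n[nH]2)cc1` differs from compound 2 in hydrogen in place of methoxy on an aromatic carbon. Among the compounds with values here, no measured step covers the loss of a single methoxy group, so its size and direction are uncertain. Compound 3 is therefore expected to give about -60%, in the range -100% to 20%, a step of a number 36 percentage points higher from compound 2 to compound 3 (beyond the scatter) toward a somewhat weaker effect.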

Compound 3, a percentage reported as activity, at one concentration (the size of the read-out at that concentration, not a potency): -79%
The estimate for compound 3 lay 19 percentage points above the measured number, and the stated range covers the measured number.
By their numbers in this assay, from the lowest: compound 2; then compound 3; then compound 1.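

In this assay the loss of one methoxy group, which turns 3,4-dimethoxyphenyl into 4-methoxyphenyl, gives a number 17 percentage points higher from compound 2 to compound 3 (beyond the scatter), a modest change at this position. Against the 3,4-dichlorophenyl group, the 4-methoxyphenyl group still gives a number 97 percentage points lower from compound 1 to compound 3 (beyond the scatter), so most of the large difference remains with only one methoxy group on the ring. Nothing available explains these differences. Open, from the compounds shown here alone, is whether an amine or a hydroxyl group in place of the lost methoxy group would hold the effect. Also open, going by these compounds, is whether a plain phenyl group would keep it.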